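Amide series: acid replaces pyridine in saphenous vein assay

This account rests on a few compounds, and the source may have more. Where it says the series, first, only, none or still open, it means among the compounds named here.

Measured so far:
compound 1 `COc1ccc(C(=O)Nc2ccc(-c3ccc(C=O)cc3C)cc2)cc1CCCN(C)C` gives 8.4 in a functional assay (Saphenous vein) with Canis familiaris (Canis lupus familiaris) as the target; a higher number here means a more potent compound, by a factor of ten per unit of this negative logarithm, a lower number a less potent compound
compound 2 `COCCOC(=O)c1ccc(-c2ccc(NC(=O)c3ccc(OC)c(CCCN(C)C)c3)cc2)c(C)c1` gives 8.4 in this assay
compound 3 `COc1ccc(C(=O)Nc2ccc(-c3ccncc3)cc2)cc1CCCN(C)C` gives 7.8 in this assay

Compound 3 stands lowest of the three numbers; its nearest neighbour is compound 1, and the step of a number 0.60 log units lower from compound 1 to compound 3 (beyond the scatter) is beyond the scatter, as is the gap to compound 2, which is of the same size.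

Compound 4 `COc1ccc(C(=O)Nc2ccc(-c3ccc(C(=O)O)cc3C)cc2)cc1CCCN(C)C` is the next structure for this assay. Its change from compound 3: 4-carboxy-2-methylphenyl in place of pyridin-4-yl on an aromatic carbon. For the measured compounds named here, two measured steps bear on it. The step of a number 0.60 log units lower from compound 1 to compound 3 (beyond the scatter) is the reverse of the ring change in question, apart from the formyl group giving way to carboxy. The step of no change at the digits printed from compound 1 to compound 2 (within the scatter) shows that altering the substituent on that carbonyl carbon left the number unchanged within the scatter. Taken together, a step up of roughly the size of the first is expected, with some allowance for the carboxy group being unmeasured.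

The estimate for compound 4 is a step of a number 0.50 log units higher from compound 3 to compound 4 (beyond the scatter), which is expected to put compound 4 at 8.3, with a range from 7.7 to 8.9.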

Compound 4, negative logarithm of the antagonist equilibrium constant: 8.7
Estimate against measurement, compound 4: 0.40 log units below; the measured number falls inside the stated range.
By their numbers in this assay, from the lowest: compound 3; then compounds 1, 2 and 4 (each within the scatter of the next).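

The ring change gives a number 0.90 log units higher from compound 3 to compound 4 (beyond the scatter) in this assay, so a free carboxy group on the 2-methylphenyl ring is compatible with this position and the pyridin-4-yl compound remains the low point of the set. On the carbonyl carbon, the steps of a number 0.30 log units higher from compound 1 to compound 4 (within the scatter) and a number 0.30 log units higher from compound 2 to compound 4 (within the scatter) do not separate hydroxy from hydrogen or 2-methoxyethoxy, so three different substituents there are indistinguishable in this assay. No measurement offered here accounts for either result.

The contributions of the methyl group and the carbonyl substituent to the ring change remain unresolved, as the step from compound 3 alters the ring and both substituents together. A plain phenyl ring, a 4-carboxyphenyl ring without the methyl, and a primary amide or nitrile in place of carboxy would each bear on that question.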